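The source may report more compounds than this note shows. Statements on the series, on what has been measured and on what is new or still open speak of the compounds shown alone.

Series on the shared core of compound 1 `CNC(=O)c1ccc(Sc2ccc(NC(=S)Nc3cccc(C(F)(F)F)c3)cc2)nc1`, varied at the group on the amide-type nitrogen, tested in a functional assay on HCT-116 cells (Homo sapiens) for cytotoxicity, read by MTT assay, with a stated time of 48 h; on this read-out lower numbers stand for stronger inhibition and higher numbers for weaker inhibition. Compound 1 gives 25900 nM. Compound 2 `CNC(=O)c1ccc(Sc2ccc(NC(=S)Nc3cccc(C)c3)cc2)nc1` gives 52400 nM, the higher of the two numbers obtained; the step of a 2.0-fold higher number from compound 1 to compound 2 (0.31 log units; beyond the scatter) is modest. Compound 3 `CNC(=O)c1ccc(Sc2ccc(NC(=S)Nc3ccc(OC(F)(F)F)cc3)cc2)nc1` reaches only a limit of the assay, > 100000 nM. Compound 4 `CNC(=O)c1ccc(Sc2ccc(NC(=S)Nc3ccc(F)c(F)c3)cc2)nc1` carries 3,4-difluorophenyl in place of 3-methylphenyl on an amide-type nitrogen. Within the data shown here, only the step from compound 1 to compound 2 bears on this change, and it was modest, so a modest step toward a lower number is expected for compound 4, a 1.4-fold lower number from compound 2 to compound 4 (0.14 log units; within the scatter). Compound 3 shows that a further change of this kind can also end at a limit. The estimate for compound 4 is 38000 nM, in the range 14000 nM to 100000 nM.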

Compound 4, half-maximal inhibitory concentration: 22200 nM
Estimate against measurement, compound 4: 1.7-fold (0.23 log units) above; low and high end bracket the measured number.
By their numbers in this assay, from the lowest: compounds 4 and 1 (each within the scatter of the next); then compound 2. At a limit, above all of these: compound 3.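

In this assay, 3,4-difluorophenyl on the amide-type nitrogen improves on 3-methylphenyl by a modest margin (a 2.4-fold lower number from compound 2 to compound 4 (0.37 log units; beyond the scatter)). Against 3-(trifluoromethyl)phenyl the change shows no separation (a 1.2-fold lower number from compound 1 to compound 4 (0.07 log units; within the scatter)), so the substituted phenyl groups of compounds 1 and 4 cannot be told apart in this assay. Compound 3 remains the only entry at a limit of the assay: the limit of > 100000 nM in this assay, at which 1 of the 4 values shown sits.

From the compounds shown here alone, whether a phenyl ring carrying an amine or a carboxylic acid would behave differently at this nitrogen stays open. A longer alkyl chain in place of the ring is equally unresolved.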